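Adding a Second Methoxy to a Cytotoxic Enaminone Scaffold

This account rests on a few compounds, and the source may have more. Where it says the series, first, only, none or still open, it means among the compounds named here.

Measured compounds:
compound 1, `COc1ccc(-c2cc(/C=C/C(=O)c3ccc(N)cc3)[nH]n2)cc1`: -61%
compound 2, `COc1cc(-c2cc(/C=C/C(=O)c3ccc(Cl)c(Cl)c3)[nH]n2)cc(OC)c1OC`: 28%

Of the compounds shown here, two have been measured in a functional assay on SF-539 cells (Homo sapiens) for cytotoxicity, read by sulforhodamine B assay, with a stated time of 48 h, tested at 10 uM; on this read-out lower numbers stand for a stronger effect and higher numbers for a weaker effect at the one concentration tested. Compound 1, `COc1ccc(-c2cc(/C=C/C(=O)c3ccc(N)cc3)[nH]n2)cc1`, gives -61% in this assay, the lowest of the two numbers shown. Compound 2, `COc1cc(-c2cc(/C=C/C(=O)c3ccc(Cl)c(Cl)c3)[nH]n2)cc(OC)c1OC`, gives 28% in this assay, a number far higher than that of compound 1 and beyond the usual scatter. Going by the values given here, compound 2 differs from compound 1 in more than one place, so its two values show only that the compounds sit far apart.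

The unmeasured compound 3, `COc1ccc(-c2cc(/C=C/C(=O)c3ccc(N)cc3)[nH]n2)cc1OC`, differs from compound 1 by methoxy in place of hydrogen on an aromatic carbon, on an aromatic carbon of a six-membered aromatic ring of carbon only, ortho to a methoxy group and meta to a large group. Among the compounds with values here, with no step between measured compounds as a guide, the expectation rests on compound 1 alone. The step from compound 1 to compound 3 in this assay is expected to be small, either none beyond the scatter or a modest move towards a weaker effect, which is what a number 11 percentage points higher from compound 1 to compound 3 (beyond the scatter) expresses. Compound 3 is therefore estimated at -50%, within -85% to -10%.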

Compound 3, a percentage reported as activity, at one concentration (the size of the read-out at that concentration, not a potency): -73%
Compound 3: the middle estimate sits 23 percentage points above what was measured; the range from low to high includes it.
By their numbers in this assay, from the lowest: compound 3; then compound 1; then compound 2.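

In this assay, methoxy in place of hydrogen on this aromatic carbon, ortho to a methoxy group and meta to a large group, gives a number 12 percentage points lower from compound 1 to compound 3 (beyond the scatter) and so the position accepts the added group, with the effect growing rather than fading. Going by these compounds alone, this is the first single change that can be read, and it shows that this part of the core of compound 1 still has room for a change that does not cost activity at the one concentration tested. Nothing available on the compounds accounts for the direction of this move.

From the compounds shown here alone, whether ethoxy, a hydroxyl group or a chlorine atom at the same carbon would match or exceed methoxy remains open, as does whether the hydrogen on the other side of the first methoxy group could be exchanged with the same result. Also open, going by these compounds, is whether the step holds when the amine of compound 1 gives way to a carboxylic acid or an acetamide at the far end of the molecule.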